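This account rests on a few compounds, and the source may have more. Where it says the series, first, only, none or still open, it means among the compounds named here.

Compound 2 `C=CCCC(=O)N[C@H]1[C@@H](OCCCCCCCCCCCCCCCC)O[C@H](CO)[C@@H](O)[C@@H]1O` is the starting point. In a functional assay on U-373MG ATCC cells (Homo sapiens), read by thymidine incorporation (a lower number here means a stronger inhibitor, a higher number a weaker inhibitor), compound 2 reaches only the limit > 50 uM, not a number. Compound 1 `CCCCCCCCCCCCCCCCO[C@H]1O[C@H](CO)[C@@H](O)[C@H](O)[C@H]1NC(C)=O` likewise gives only the limit > 50 uM in this assay. The step that the two limits leave unreadable from compound 1 to compound 2 is unreadable, since both ends sit at the limit of > 50 uM in this assay, at which 2 of the 3 values shown sit. Among the compounds with values here, compound 3 `CCCCCCCCCCCCCCCCO[C@H]1O[C@H](COCC(O)CO)[C@@H](O)[C@H](O)[C@H]1NC(=O)CCCC` differs from compound 2 in two places, and no single step connects the two; in this assay compound 3 gives 4.6 uM. Compound 4 `C=CCCC(=O)N[C@H]1[C@@H](OCCCCCCCCCCCCCCCC)O[C@H](CO)[C@@H](O)[C@@H]1OS(=O)(=O)O` changes compound 2 by sulfo in place of hydrogen on an oxygen on a saturated carbon. Within the data shown here, no measured step touches this oxygen, and the only single step in hand, a step that the two limits leave unreadable from compound 1 to compound 2, carries no readable size, so the expectation for compound 4 rests on compound 2 alone. Compound 4 is thus expected to remain at the limit, estimated at 60 uM within 10 uM to 300 uM in this assay, a step that the limit leaves unreadable from compound 2 to compound 4 expected to fall within the scatter.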

Compound 4, concentration for 50% inhibition: 33 uM
Compound 4: the middle estimate sits 1.8-fold (0.26 log units) above what was measured; the range from low to high includes it.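

In this assay, within the data shown here, hydroxy to sulfooxy on this oxygen is the first single change to leave the limit and give a number, a step (an at least 1.5-fold lower number from compound 2 to compound 4 (0.18 log units; that floor lies within the scatter)) whose true size remains unknown. Compound 2 gives only a limit, > 50 uM, not a number. The readable floor therefore establishes no change beyond the scatter.

Open, as far as these compounds go, is whether a phosphate or a carboxylic acid on this oxygen would give a step beyond the scatter. Also open, from the compounds shown here alone, is what sulfooxy does on the core of compound 3.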